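The compounds below may be only part of what the source reports. "The series", "measured", "known", "first", "only" and "open" are said of these compounds alone.

Values so far in a physicochemical assay for solubility; a lower number here means a less soluble compound, a higher number a more soluble compound 
Compound 1 (`COc1ccc(-n2cnc3cnc(-c4ccc(F)cc4C)cc32)cn1`) gives > 200000 nM (a limit)
Compound 2 (`COc1cnc(-n2cnc3cnc(-c4ccc(F)cc4C)cc32)cn1`) gives 16000 nM (a measured number)

Among the measured compounds shown here, compound 2 holds the only actual number so far (16000 nM). The one other result, that of compound 1, is a limit. Compound 3 (`COc1ncc(-n2cnc3cnc(-c4ccc(F)cc4C)cc32)cn1`) carries 2-methoxypyrimidin-5-yl in place of 5-methoxypyrazin-2-yl on an aromatic nitrogen, the same atoms joined differently. For the measured compounds named here, one measured step bears on this place, a large one, with an at least 12-fold lower number from compound 1 to compound 2 (1.09 log units; beyond the scatter) for another exchange of this group. Going by these compounds, its true size stays open, resting on the limit of > 200000 nM in this assay, at which 1 of the 2 values shown sits, as it does. That single step, from compound 1 to compound 2 (an at least 12-fold lower number from compound 1 to compound 2 (1.09 log units; beyond the scatter)), shows the number can move far at this place, so a moderate upward move is expected, with wide uncertainty. The estimated change is a 2.5-fold higher number from compound 2 to compound 3 (0.40 log units; beyond the scatter) on this reading. Compound 3 is estimated at 40000 nM (range 9000 nM to 180000 nM).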

Compound 3, solubility: > 200000 nM
Compound 3: only a limit was reported (the forecaster's own chance of this, stated with the estimate: 12%); middle value at least 5.0-fold (0.69 log units) away from the limit.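

In this assay, 2-methoxypyrimidin-5-yl in place of 5-methoxypyrazin-2-yl gives an at least 12-fold higher number from compound 2 to compound 3 (1.09 log units; beyond the scatter). The two groups have the same atoms and the same counts of donors and acceptors, so at this place on the aromatic nitrogen a change in how the atoms are joined is enough for a large step, which the earlier exchange, with a different count of ring nitrogens, could not show. The true size of this step stays open and the step between compound 1 and compound 3 cannot be read: the limit of > 200000 nM in this assay, at which 2 of the 3 values shown sit.

Still open, going by these compounds, is how far the number lies above the limit for compound 3. Also open, on these data alone, is whether an ethoxy group or an amine in place of the methoxy on the 2-methoxypyrimidin-5-yl would leave the number there.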